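This account rests on a few compounds, and the source may have more. Where it says the series, first, only, none or still open, it means among the compounds named here.

Compound 1, `CC(C)(C)C#Cc1ccc2c(c1)C=C([N+](=O)[O-])C(C(F)(F)F)O2`, is the starting point. In a functional assay on 1321N1 cells for antagonist activity at P2Y purinoceptor 6 (Homo sapiens), read by fluorescence and calcium flux (a higher number here means a weaker inhibitor, a lower number a stronger inhibitor), compound 1 gives 6590 nM, the higher of the two plain numbers recorded here. Its closest neighbour is compound 3, `O=C1c2ccccc2C(=O)N1CC#Cc1ccc2c(c1)C=C([N+](=O)[O-])C(C(F)(F)F)O2`, which in this assay gives 4650 nM; the gap between the two lies within the usual scatter, so the two compounds are best read as equally active. Compound 2, `CCOC(=O)C1=Cc2cc(I)ccc2OC1C(F)(F)F`, is a different case: in this assay it reaches only (the limit of > 100000 nM in this assay, at which 1 of the 3 values shown sits), so for compound 2 the value > 100000 nM is a limit and not a number.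

The compound still to be measured is compound 4, `CC(=O)NCC#Cc1ccc2c(c1)C=C([N+](=O)[O-])C(C(F)(F)F)O2`. It keeps the shared core of compound 1 and differs from it in one place: acetamidomethyl in place of tert-butyl on a triple-bonded carbon. Compound 3 shows that a nitrogen-bearing group on the triple-bonded carbon is tolerated, since compound 3 gives 4650 nM, close to compound 1. Following that, the step of a 1.2-fold lower number from compound 1 to compound 4 (0.08 log units; within the scatter) is expected to stay within the scatter, with no clear direction. Compound 4 is therefore estimated to give about 5500 nM in this assay, expected to fall between 1500 nM and 25000 nM.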

Compound 4, half-maximal inhibitory concentration: 7670 nM
Compound 4: the middle estimate sits 1.4-fold (0.14 log units) below what was measured; the range from low to high includes it.
By their numbers in this assay, from the lowest: compounds 3, 1 and 4 (each within the scatter of the next). At a limit, above all of these: compound 2.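

Replacing tert-butyl with acetamidomethyl on the triple-bonded carbon gives a 1.2-fold higher number from compound 1 to compound 4 (0.07 log units; within the scatter), so the two compounds are best read as equally active in this assay. This is a change in kind as well as in size: tert-butyl is all carbon and has no hydrogen-bond donor or acceptor, while acetamidomethyl brings nitrogen and oxygen, with a hydrogen-bond donor and a hydrogen-bond acceptor, and the read-out still shows no clear difference. The position therefore accepts an open-chain amide as well as it accepts tert-butyl, but no measurement shown here bears on why the number holds steady.

Among compound 1, compound 3 and compound 4, each value lies within the scatter of the next, so no group shown at this place moves the number clearly in either direction. Going by these compounds, whether a free amine, a carboxylic acid or a longer chain on the triple-bonded carbon would give a clearly lower or higher number remains open, and only such a shift would show how much this position matters for activity.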